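The source may report more compounds than this note shows. Statements on the series, on what has been measured and on what is new or still open speak of the compounds shown alone.

Values in a functional assay on KG-1 cells (Homo sapiens) for cytotoxicity, read by luminescence and CellTiter-Glo, with a stated time of 3 days; a higher number here means a weaker inhibitor, a lower number a stronger inhibitor
compound 1 `N#Cc1ccc(NC(=O)c2ccc3cccnc3c2O)c(F)c1` gives 3260 nM
compound 2 `Cc1cc(C#N)ccc1NC(=O)c1ccc2cccnc2c1O` gives 3240 nM
compound 3 `N#Cc1ccc(NC(=O)c2ccc3cccnc3c2O)cc1` gives 2320 nM

Compound 3 cannot be separated from the other two compounds on these numbers: both of its steps (a 1.4-fold lower number from compound 1 to compound 3 (0.15 log units; within the scatter)) and (a 1.4-fold lower number from compound 2 to compound 3 (0.15 log units; within the scatter)) stay within the scatter. Compound 4 `N#Cc1ccc(NC(=O)c2ccc3cccnc3c2O)c(C#N)c1` differs from compound 3 by cyano in place of hydrogen on an aromatic carbon. Compound 1 and compound 2 carry fluoro and methyl on that same carbon, so these two steps, read in reverse, are the nearest evidence, together with the step between those two compounds (a 1.0-fold lower number from compound 1 to compound 2 (0.00 log units; within the scatter)). Among the compounds with values here, no compound with cyano on that carbon has been measured, so the range is kept wide. In this assay no step beyond the scatter is expected. The estimated step is small (a 1.3-fold higher number from compound 3 to compound 4 (0.10 log units; within the scatter)). For compound 4 the estimated value is 2900 nM with an expected range (1300 nM to 6500 nM).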

Compound 4, half-maximal inhibitory concentration: 3770 nM
For compound 4 the middle estimate is 1.3-fold (0.11 log units) below the measured one; low and high end bracket the measured number.
By their numbers in this assay, from the lowest: compounds 3, 2, 1 and 4 (each within the scatter of the next).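

In this assay, cyano on this aromatic carbon, ortho to a large group, gives no step beyond the scatter against any of the three earlier groups: hydrogen (a 1.6-fold higher number from compound 3 to compound 4 (0.21 log units; within the scatter)), methyl (a 1.2-fold higher number from compound 2 to compound 4 (0.07 log units; within the scatter)) and fluoro (a 1.2-fold higher number from compound 1 to compound 4 (0.06 log units; within the scatter)). The earlier compounds shown here showed this only for fluoro, methyl and hydrogen; with cyano, a group containing a triple bond, the four compounds at this carbon still cannot be separated on these numbers. Nothing available accounts for this flat result.

As far as these compounds go, whether an amine, a carboxylic acid or a longer chain on this carbon would give a step beyond the scatter remains open. Also open, from the compounds shown here alone, is whether any change elsewhere on the shared core would move the number further than these changes do.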